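The compounds below may be only part of what the source reports. "The series", "measured", "known", "first", "only" and "open" are said of these compounds alone.

Measured so far:

- compound 1, `O=C(/C=C/c1ccc(OCc2cn(Cc3cccc(Br)c3)nn2)cc1)c1ccc(Br)cc1`: 36%
- compound 2, `O=C(/C=C/c1ccc(OCc2cn(Cc3ccccc3)nn2)cc1)c1ccc([N+](=O)[O-])cc1`: "not active" (no number reported)
- compound 3, `O=C(/C=C/c1ccc(OCc2cn(Cc3ccccc3Br)nn2)cc1)c1ccc([N+](=O)[O-])cc1`: 43%

The series shares one core and varies two ends: the aryl group on the ketone and the benzyl group on the triazole nitrogen. In a functional assay on MCF7 cells (Homo sapiens) for inhibition, read by MTT assay, with a stated time of 48 h, tested at 10 uM (a higher number here means more inhibition of growth at the concentration tested, a lower number less inhibition of growth), compound 3 gives 43%. In this assay compound 1 gives 36%; the gap between compound 3 and compound 1 lies within the usual scatter, so the two cannot be placed in order. Compound 2, which carries an unsubstituted benzyl group, is reported as "not active" (no number reported) in this assay and gives no number to compare.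

Compound 4, `O=C(/C=C/c1ccc(OCc2cn(Cc3cccc(Br)c3)nn2)cc1)c1ccc([N+](=O)[O-])cc1`, has not been measured. It differs from compound 3 in one place: 3-bromophenyl in place of 2-bromophenyl on a saturated chain carbon bound to an aromatic nitrogen. Among the compounds with values here, no measured pair in the set isolates this change, so its size is unknown. Compound 4 combines the benzyl group of compound 1 with the ketone aryl group of compound 3, and both of those compounds sit within the scatter of each other, while compound 2 shows that removing bromine from the benzyl group can remove the measurable effect. The step from compound 3 to compound 4 is therefore expected to stay within the scatter, a number 7 percentage points lower from compound 3 to compound 4 (within the scatter), with some chance of a loss. Compound 4 is estimated at 36%, with a range from 15% to 50%.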

Compound 4, percent growth inhibition at one concentration: 12%
The estimate for compound 4 lay 24 percentage points above the measured number, outside the stated range (below it).
By their numbers in this assay, from the lowest: compound 4; then compounds 1 and 3 (each within the scatter of the next).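

In this assay the two bromobenzyl isomers do not read alike: 3-bromophenyl in place of 2-bromophenyl on a saturated chain carbon bound to an aromatic nitrogen gives a number 31 percentage points lower from compound 3 to compound 4 (beyond the scatter), although the two compounds have the same atoms, joined differently. With the 3-bromobenzyl group held fixed, nitro in place of bromo on an aromatic carbon gives a number 24 percentage points lower from compound 1 to compound 4 (beyond the scatter), so the outcome of this pair also depends on the group at the ketone aryl end. A bromine on the benzyl group is therefore not enough on its own to keep growth inhibition at the level of compound 3, while steps involving compound 2, which has no number, cannot be read.

Still open, going by these compounds, is whether the change from 2-bromobenzyl to 3-bromobenzyl has a similar size with bromo on the ketone aryl group, and how chloro, methoxy or an amine would read in place of the bromine on the benzyl ring. No supporting measurement bears on the reason for these steps.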